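The compounds below may be only part of what the source reports. "The series", "measured", "known", "first", "only" and "open" are said of these compounds alone.

Compound 1 is `CCc1ccccc1N(Cc1nnc(Cc2ccccc2)o1)S(=O)(=O)c1ccc(C)cc1`; in an assay on CHO cells for displacement of a labelled ligand from prostaglandin E2 receptor EP1 subtype (Homo sapiens) (a lower number here means a stronger inhibitor, a higher number a weaker inhibitor), compound 1 gives 1000 nM.
Compound 2 is `CCOc1ccc(Cc2nnc(CN(c3ccccc3CC)S(=O)(=O)c3ccc(C)cc3)o2)cc1`; in this assay compound 2 gives 126 nM.
Compound 3 is `Cc1ccc(S(=O)(=O)N(Cc2nnc(Cc3ccc(C(F)(F)F)cc3)o2)c2cccc(Cl)c2C)cc1`; in this assay compound 3 gives 50.1 nM.

Compound 3 has the lowest number of the three, with compound 2 the nearest and compound 1 the furthest. Within the data shown here, the only single-place step among them is a 7.9-fold lower number from compound 1 to compound 2 (0.90 log units; beyond the scatter), which concerns the ring of the benzyl group on the shared core. Compound 4, `Cc1ccc(S(=O)(=O)N(Cc2nnc(Cc3c(Cl)cccc3Cl)o2)c2cccc(Cl)c2C)cc1`, differs from compound 3 by 2,6-dichlorophenyl in place of 4-(trifluoromethyl)phenyl on a saturated chain carbon bound to an aromatic carbon. Among the measured compounds shown here, that is a change on the same benzyl ring, but no measured pair isolates a swap of a 4-(trifluoromethyl)phenyl for a 2,6-dichlorophenyl, and compound 1 and compound 3 differ in more than one place, so their values give no clean reading. The step from compound 1 to compound 2 shows that this ring can move the number by a modest amount, so a step of at most modest size is expected for compound 4, with its direction uncertain, as a 1.2-fold higher number from compound 3 to compound 4 (0.08 log units; within the scatter). Compound 4 is therefore estimated at 60 nM, within 20 nM to 250 nM.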

Compound 4, half-maximal inhibitory concentration: 63.1 nM
Beside the measured number, compound 4's estimate is 1.1-fold (0.02 log units) below it; the range from low to high includes it.
By their numbers in this assay, from the lowest: compounds 3, 4 and 2 (each within the scatter of the next, the first and the last beyond it); then compound 1.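

In this assay, 2,6-dichlorophenyl in place of 4-(trifluoromethyl)phenyl on a saturated chain carbon bound to an aromatic carbon gives a 1.3-fold higher number from compound 3 to compound 4 (0.10 log units; within the scatter), so on the core of compound 3 these two differently substituted rings cannot be told apart. The earlier step, a 7.9-fold lower number from compound 1 to compound 2 (0.90 log units; beyond the scatter), showed only that ethoxy in place of hydrogen on this ring goes with a shift beyond the scatter, whereas this pair shows that a change of the whole substituted ring need not shift the number at all. Nothing measured here bears on why the two values agree. From the compounds shown here alone, whether this tolerance extends to a ring carrying an amine or a carboxylic acid remains open. Also open, going by these compounds, is whether ethoxy in place of hydrogen would give the same step on the core of compound 3 as on the core of compound 1.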